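The compounds below may be only part of what the source reports. "The series", "measured", "known", "first", "only" and "open" are said of these compounds alone.

Going by the values given here, compound 2 `O=C(CSc1nnnn1-c1cccc2ccccc12)N/N=C/c1ccccc1Cl` is one of two compounds measured in an ADME assay on MT4 cells (Homo sapiens) for cytotoxicity, read by MTT assay (on this read-out lower numbers stand for higher toxicity in this test and higher numbers for lower toxicity in this test), in which compound 2 gives 69700 nM. Among the compounds with values here, its only neighbour is compound 1 `O=C(CSc1nnnn1-c1cccc2ccccc12)N/N=C/c1cccc(Cl)c1`, which in this assay gives 240000 nM; the step of a 3.4-fold lower number from compound 1 to compound 2 (0.54 log units; beyond the scatter) came with the move of the chloro group. Compound 3 `O=C(CSc1nnnn1-c1cccc2ccccc12)N/N=C/c1ccccc1F` differs from compound 2 by fluoro in place of chloro on an aromatic carbon. Within the data shown here, no measured step covers this exchange, so an estimate for compound 3 in this assay rests on compound 2 alone, and a change of a 1.3-fold higher number from compound 2 to compound 3 (0.11 log units; within the scatter) is expected, which is within the scatter. Compound 3 is therefore estimated at 90000 nM, between 35000 nM and 250000 nM.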

Compound 3, half-maximal cytotoxic concentration: >= 118000 nM
Compound 3: only a limit was reported; the forecaster's own chance of this, stated with the estimate: 10%; middle value at least 1.3-fold (0.11 log units) away from the limit.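

Compound 3 is reported only as a limit in this assay: the limit of >= 118000 nM in this assay, at which 1 of the 3 values shown sits. At this place, ortho to a large group, fluoro in place of chloro gives an at least 1.6-fold higher number from compound 2 to compound 3 (0.22 log units; that floor lies within the scatter), so the limit does not establish a real difference, though it leaves room for one. The step between compound 1 and compound 3 cannot be read.

The compounds shown leave open how far past its limit compound 3 lies. They also leave open how a methyl, a methoxy or an amine on this aromatic carbon would read in this assay.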